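The source may report more compounds than this note shows. Statements on the series, on what has been measured and on what is new or still open speak of the compounds shown alone.

Measured so far:
compound 1 `COc1ccc(CN(C(=O)C(C)Br)c2cc(OC)c(OC)c(OC)c2)cc1O`: 160 nM
compound 2 `CC/C=C/C(=O)N(Cc1ccc(OC)c(O)c1)c1cc(OC)c(OC)c(OC)c1`: 72 nM

Going by the values given here, in a functional assay on KYSE-450 cells (Homo sapiens) for inhibition, read by MTT assay, with a stated time of 48 h (on this read-out higher numbers stand for weaker inhibition and lower numbers for stronger inhibition), compound 2 stands at the lower of the two numbers, with compound 1 at 160 nM as its only neighbour, and a 2.2-fold lower number from compound 1 to compound 2 (0.35 log units; beyond the scatter). Compound 3 `COc1ccc(CN(C(=O)C(C)C)c2cc(OC)c(OC)c(OC)c2)cc1O` is not yet measured. It differs from compound 2 in one place: isopropyl in place of but-1-en-1-yl on a carbonyl carbon. Among the compounds with values here, the only measured step touching this carbonyl carbon is a 2.2-fold lower number from compound 1 to compound 2 (0.35 log units; beyond the scatter), a modest one, and neither of its groups is isopropyl, so the guide is weak. For compound 3 a modest move toward a higher number is expected, a 2.8-fold higher number from compound 2 to compound 3 (0.44 log units; beyond the scatter). Compound 3 is therefore estimated at 200 nM, within a range from 70 nM to 600 nM.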

Compound 3, half-maximal inhibitory concentration: 390 nM
For compound 3 the middle estimate is 2.0-fold (0.29 log units) below the measured one, and the stated range covers the measured number.
By their numbers in this assay, from the lowest: compound 2; then compound 1; then compound 3.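

In this assay, isopropyl in place of but-1-en-1-yl on the carbonyl carbon gives a 5.4-fold higher number from compound 2 to compound 3 (0.73 log units; beyond the scatter), the largest of the three steps at this position. Methyl in place of bromo on the chain also raises the number, with a 2.4-fold higher number from compound 1 to compound 3 (0.39 log units; beyond the scatter), so isopropyl ranks behind both 1-bromoethyl and but-1-en-1-yl here. Still open, as far as these compounds go, is whether the double bond or the chain length of but-1-en-1-yl matters more, which a saturated butyl chain could separate, and how an amine at this place would fare. Nothing measured here explains this ranking.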